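Toxicity Check on a Series of Biaryl Amides

A few compounds are considered here, and "the series" means these few. Any claim that something is new, unique, unknown or untested is made for them only; others in the source may bear on it.

Compound 1, `CC(C)N(Cc1cccc(OCCCCCC(=O)O)c1)C(=O)c1ccc(-c2cccc(OCc3ccccc3)c2)cc1`: > 26000 nM
Compound 2, `Cc1nnc(-c2cccc(-c3ccc(C(=O)N(Cc4cccc(OCCCCCC(=O)O)c4)C(C)C)cc3)c2)o1`: > 26000 nM
Compound 3, `CCOC(=O)CCCCCOc1cccc(CN(C(=O)c2ccc(-c3cccnc3)cc2)C(C)C)c1`: > 26000 nM

All three compounds were tested in an ADME assay on BJ cells (Homo sapiens) for cytotoxicity, read by CellTiter-Glo and resazurin assay, with a stated time of 72 h; on this read-out lower numbers stand for an effect already at smaller amounts and higher numbers for an effect only at larger amounts of compound. The value for compound 1 is a limit of the assay, not a number. The value for compound 2 is also a limit. The value for compound 3 is a limit as well. Each of the three values sits at the limit of > 26000 nM in this assay, at which 3 of the 3 values shown sit, so none of them reports an actual concentration.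

Among the measured compounds shown here, the only pair differing in one place is compound 1 and compound 2, and its step that the two limits leave unreadable from compound 1 to compound 2 cannot be read because both ends are limits (the limit of > 26000 nM in this assay, at which 3 of the 3 values shown sit). Compound 3 therefore stands where the other two stand: at the limit, with no number to compare.

Compound 4, `CCOC(=O)CCCCCOc1cccc(CN(C(=O)c2ccc(-c3cccc(OC)c3)cc2)C(C)C)c1`, differs from compound 3 by 3-methoxyphenyl in place of pyridin-3-yl on an aromatic carbon. For the measured compounds named here, no measured step bears on this change with a readable size, since the one step in the set is unreadable. Compound 4 is expected to remain at the limit of this assay, giving an estimated 40000 nM with a range of 20000 nM to 100000 nM. The step that the limit leaves unreadable from compound 3 to compound 4 that this estimate implies is expected to be no more than none beyond the scatter, because compound 3 itself gives only > 26000 nM as a limit.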

Compound 4, half-maximal effective concentration: > 21000 nM
Compound 4 was reported as a limit (the forecaster's own chance of this, stated with the estimate: 85%); the middle value lies beyond the limit too.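

In this assay compound 3 and compound 4 are both reported as limits rather than numbers, so the step from pyridin-3-yl to 3-methoxyphenyl cannot be read. The compounds shown leave open the concentration, if any, at which each would produce a half-maximal effect, and whether this change in structure alters it.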